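This account rests on a few compounds, and the source may have more. Where it says the series, first, only, none or still open, it means among the compounds named here.

Working notes on the series. For the measured compounds named here, compound 1 `CC(C)(C)OC(=O)NCC1CCCN(C(=O)CN2CN(c3ccccc3)C3(CCN(C(=O)c4ccc(C5CCCCC5)cc4)CC3)C2=O)C1` gives 3800 nM in an assay on HEK293 cells for displacement of a labelled ligand from NPC1-like intracellular cholesterol transporter 1 (Homo sapiens); on this read-out lower numbers stand for stronger inhibition and higher numbers for weaker inhibition; compound 3 `O=C(CN1CN(c2ccccc2)C2(CCN(C(=O)c3ccc(C4CCCCC4)cc3)CC2)C1=O)N1CCCCC1` gives 1100 nM, and the one step measured in this set, a 3.5-fold lower number from compound 1 to compound 3 (0.54 log units; beyond the scatter), is the only guide to size so far. Compound 2 `CC(C)(C)c1ccc(C(=O)N2CCC3(CC2)C(=O)N(CC(=O)NCCC(=O)O)CN3c2ccccc2)cc1` gives 11400 nM, the highest of the three numbers, with compound 1 nearest and compound 3 furthest.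

Compound 4 `CC(C)(C)c1ccc(C(=O)N2CCC3(CC2)C(=O)N(CC(=O)N2CCCCC2CO)CN3c2ccccc2)cc1` is not yet measured. It differs from compound 2 by 2-(hydroxymethyl)piperidin-1-yl in place of (2-carboxyethyl)amino on a carbonyl carbon. Going by the values given here, no measured step covers this change; compound 3, which also carries a piperidine amide, differs from compound 2 in more than one place, so only its value can be set beside that of compound 2. On that basis the number for compound 4 is expected to fall, as a 3.3-fold lower number from compound 2 to compound 4 (0.51 log units; beyond the scatter). Compound 4 is estimated at 3500 nM, within 1200 nM to 10000 nM.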

Compound 4, half-maximal inhibitory concentration: 11800 nM
Compound 4: middle estimate off by 3.4-fold (0.53 log units), on the low side; measured number above the stated range.
By their numbers in this assay, from the lowest: compound 3; then compound 1; then compounds 2 and 4 (each within the scatter of the next).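

On the carbonyl carbon, 2-(hydroxymethyl)piperidin-1-yl in place of (2-carboxyethyl)amino reads as a 1.0-fold higher number from compound 2 to compound 4 (0.01 log units; within the scatter) in this assay, so these two groups cannot be told apart at this position. With the rest of the structure held constant, an open chain carrying a carboxylic acid and a six-membered ring carrying hydroxymethyl give values within the scatter of each other. Nothing available explains this agreement.

As far as these compounds go, whether a morpholin-4-yl group or a longer chain ending in a carboxylic acid on this carbonyl carbon would separate from these two values remains open. Also open, from the compounds shown here alone, is what the hydroxymethyl on the piperidine contributes on its own.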